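Swapping the Ring Nitrogen Substituent of Compound 3

The source may report more compounds than this note shows. Statements on the series, on what has been measured and on what is new or still open speak of the compounds shown alone.

Compound 1 `COC(=O)CC(=O)N1N=C(c2ccc(N3CCN(C)CC3)cc2)CC1c1ccc(N(C)C)cc1`: -8.3%
Compound 2 `C=C(C)C(=O)N1N=C(c2ccc(-n3ccnc3)cc2)CC1c1ccc(N(C)C)cc1`: 1.6%
Compound 3 `COC(=O)CC(=O)N1N=C(c2ccc(-n3ccnc3)cc2)CC1c1ccc(N(C)C)cc1`: 2.1%

In a functional assay on HCC1806 cells (Homo sapiens) for inhibition, read by sulforhodamine B assay, tested at 10 uM (a higher number here means more inhibition at the concentration tested (going by the name of the read-out), a lower number less inhibition), compound 3 stands at the upper end of the three numbers, with compound 2 within the scatter of it and compound 1 lower beyond it, as a number 10.4 percentage points higher from compound 1 to compound 3 (beyond the scatter) shows. Compound 4 `Cc1ccc(S(=O)(=O)N2N=C(c3ccc(-n4ccnc4)cc3)CC2c2ccc(N(C)C)cc2)cc1` differs from compound 3 by (4-methylphenyl)sulfonyl in place of ((methoxycarbonyl)methyl)carbonyl on an amine nitrogen in a ring. For the measured compounds named here, the only measured step at this position is a number 0.5 percentage points higher from compound 2 to compound 3 (within the scatter), where the group on the ring nitrogen was exchanged and the number stayed within the scatter. Going by the values given here, no measured step replaces a carbonyl with a sulfonyl or adds an aromatic ring at this place, so the expectation rests on that single small step alone. Compound 4 is therefore expected to give 2%, between -10% and 14%. The step of a number 0.1 percentage points lower from compound 3 to compound 4 (within the scatter) is expected to stay within the scatter.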

Compound 4, a percentage reported as inhibition, at one concentration (the size of the read-out at that concentration, not a potency): 66%
Beside the measured number, compound 4's estimate is 64 percentage points below it; measured number above the stated range.
By their numbers in this assay, from the lowest: compounds 1, 2 and 3 (each within the scatter of the next, the first and the last beyond it); then compound 4.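

In this assay the group at this amine nitrogen in a ring proves decisive: (4-methylphenyl)sulfonyl in place of ((methoxycarbonyl)methyl)carbonyl gives a number 63.9 percentage points higher from compound 3 to compound 4 (beyond the scatter), and in place of (1-methylethenyl)carbonyl it gives a number 64.4 percentage points higher from compound 2 to compound 4 (beyond the scatter). The two carbonyl-linked groups had stayed within the scatter of each other, so only the sulfonyl group with its aromatic ring separates from them. Nothing available explains this rise. The compounds shown leave open whether the sulfonyl link or the aromatic ring carries the step. A benzoyl or a methanesulfonyl group on the same nitrogen would separate the two.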